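The source may hold more compounds than are shown below. What is called first, only, known or untested is meant among the compounds shown, and "the series" means these compounds.

In a functional assay on HT-29 cells (Homo sapiens) for cytotoxicity, read by XTT assay, with a stated time of 72 h (a higher number here means a weaker inhibitor, a lower number a stronger inhibitor), compound 1 `CCn1ccc2cc(C(O)c3ccc(OC)c(OC)c3OC)ccc21` gives > 10000 nM, which is a limit and not a number. Among the measured compounds shown here, compound 2 `CCn1ccc2cc(/C(=N/O)c3ccc(OC)c(OC)c3OC)ccc21` gives 2000 nM in this assay, the only actual number so far, so its standing cannot yet be ranked against a second measured value. Compound 3 `CCn1ccc2cc(/C(=N/N)c3ccc(OC)c(OC)c3OC)ccc21` carries one change from compound 2: amino in place of hydroxy on a double-bonded nitrogen, with amino in place of hydroxy on a double-bonded nitrogen. For the measured compounds named here, no measured step covers this exchange, so the expectation rests on the value of compound 2 and on the structural change alone. No shift beyond the usual scatter is expected in this assay, and any small movement would more likely be toward a stronger inhibitor. The estimated step is a 1.3-fold lower number from compound 2 to compound 3 (0.12 log units; within the scatter). For compound 3 the expected value is 1500 nM, with an estimated range of 300 nM to 8000 nM.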

Compound 3, half-maximal inhibitory concentration: > 10000 nM
Compound 3 gave a limit, no number (the forecaster's own chance of this, stated with the estimate: 15%); middle value at least 6.6-fold (0.82 log units) away from the limit.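

In this assay, among the compounds shown here, the exchange on the double-bonded nitrogen gives the first reading at this position: amino in place of hydroxy produces an at least 5.0-fold higher number from compound 2 to compound 3 (0.69 log units; beyond the scatter). Hydroxy and amino match in heavy atoms and in hydrogen-bond donors and acceptors, and neither carries a net charge, so these counts alone do not account for the step. Compound 3 gives a limit and not a number, so the full size of the step cannot be read: the limit of > 10000 nM in this assay, at which 2 of the 3 values shown sit.

The compounds shown carry only hydroxy and amino on this nitrogen, and whether a methoxy group there would stand with compound 2 or with compound 3 remains open. Also open, going by these compounds, is whether the step would hold with any other change to the shared core.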